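Isobutoxy in place of 2-chlorobenzyloxy: compound 4

The source may report more compounds than this note shows. Statements on the series, on what has been measured and on what is new or still open speak of the compounds shown alone.

Measured so far in a functional assay on HEK293 cells for agonist activity at G-protein coupled receptor 39 (Homo sapiens), read by scintillation proximity assay and inositol phosphate accumulation, with a stated time of 75 min, in the presence of a further agent that is not named here; a higher number here means that more compound is needed for the effect, a lower number that less compound is needed:
Compound 1, `Cc1nn(-c2ncnc3nc[nH]c23)c2c1C(OCc1ccc(C#N)cc1)CC(=O)N2`, gives 4 nM.
Compound 2, `Cc1nn(-c2ncnc3nc[nH]c23)c2c1C(NC(=O)Cc1cccs1)CC(=O)N2`, gives 3 nM.
Compound 3, `Cc1nn(-c2ncnc3nc[nH]c23)c2c1C(OCc1ccccc1Cl)CC(=O)N2`, gives 2 nM.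

Compound 3 carries the lowest of the three numbers, but the gaps to its neighbours are small: a 1.5-fold lower number from compound 2 to compound 3 (0.18 log units; within the scatter) and a 2.0-fold lower number from compound 1 to compound 3 (0.30 log units; within the scatter), both within the scatter, so the three measured compounds cannot be put in an order. The remaining step, a 1.3-fold lower number from compound 1 to compound 2 (0.12 log units; within the scatter), is likewise within the scatter. Every measured step exchanges one aromatic or heteroaromatic fragment for another at the same ring position of the shared core, in one case together with a change of the linking group, and none of them shifts the number beyond the scatter.

Compound 4, `Cc1nn(-c2ncnc3nc[nH]c23)c2c1C(OCC(C)C)CC(=O)N2`, differs from compound 3 as follows: isopropyl in place of 2-chlorophenyl on a saturated chain carbon bound to an oxygen on a saturated carbon. Among the measured compounds shown here, no measured step covers this kind of change: the ring is removed altogether rather than exchanged, so the tolerance seen among compounds 1, 2 and 3 is only indirect guidance. A somewhat higher number than for compound 3 is expected in this assay, with wide uncertainty in both directions.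

For compound 4 the expected value in this assay is 15 nM, with a range from 3 nM to 100 nM, corresponding to an expected step of a 7.5-fold higher number from compound 3 to compound 4 (0.88 log units; beyond the scatter).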

Compound 4, half-maximal effective concentration: 4 nM
For compound 4 the middle estimate is 3.8-fold (0.57 log units) above the measured one; the range from low to high includes it.
By their numbers in this assay, from the lowest: compounds 3, 2, 1 and 4 (each within the scatter of the next).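

At the saturated chain carbon bound to an oxygen on a saturated carbon, isopropyl in place of 2-chlorophenyl takes away the six-membered aromatic ring of carbon only and the chlorine, and in this assay the step stays small (a 2.0-fold higher number from compound 3 to compound 4 (0.30 log units; within the scatter)). The other two comparisons read the same way: isopropyl in place of 4-cyanophenyl (no change at the digits printed from compound 1 to compound 4 (within the scatter)) and isobutoxy in place of (((thiophen-2-yl)methyl)carbonyl)amino on a saturated ring carbon (a 1.3-fold higher number from compound 2 to compound 4 (0.12 log units; within the scatter)). The earlier compounds only exchanged one ring-bearing group for another, whereas compound 4 shows that a ring in this group is not required for a number within the scatter of theirs, though the data available here offer no reason for this tolerance.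

Still open, as far as these compounds go, is how far the group can be reduced or extended: the hydroxyl or methoxy at this carbon, a longer chain such as n-hexyloxy, or a chain ending in an amine or a carboxylic acid. From the compounds shown here alone, all four compounds also share the rest of the core, so whether isobutoxy is tolerated equally with other groups elsewhere on it remains unknown.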